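The source may report more compounds than this note shows. Statements on the series, on what has been measured and on what is new or still open speak of the compounds shown alone.

In a functional assay (Homo sapiens) for inhibition, read by sulforhodamine B assay, with a stated time of 3 days (a lower number here means a stronger inhibitor, a higher number a weaker inhibitor), three compounds on one shared core have been measured: compound 1 (`O=C1CN(c2nc(N3CCCC3)c3nc(Cl)c(NCc4ccccc4)nc3n2)CCN1`) gives 9500 nM, compound 2 (`NCCNc1nc(N2CCCC2)c2nc(Cl)c(NCc3ccccc3)nc2n1`) gives 3200 nM and compound 3 (`OCCNc1nc(N2CCCC2)c2nc(Cl)c(NCc3ccccc3)nc2n1`) gives 15200 nM. Two steps place that last value: a 1.6-fold higher number from compound 1 to compound 3 (0.20 log units; within the scatter), and a 4.8-fold higher number from compound 2 to compound 3 (0.68 log units; beyond the scatter). Compound 4 (`CN(C)c1nc(N2CCCC2)c2nc(Cl)c(NCc3ccccc3)nc2n1`) carries dimethylamino in place of (2-hydroxyethyl)amino on an aromatic carbon. Within the data shown here, no measured step makes this exact exchange. The nearest evidence is the other exchanges on that carbon, including a 3.0-fold lower number from compound 1 to compound 2 (0.47 log units; beyond the scatter). Compound 4 has neither the hydroxy of compound 3 nor the primary amino of compound 2. The expected step in this assay, a 1.7-fold lower number from compound 3 to compound 4 (0.23 log units; within the scatter), is therefore small, probably towards a lower number and not beyond the scatter. For compound 4 the estimated value is 9000 nM, with an expected range of 3500 nM to 22000 nM.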

Compound 4, half-maximal inhibitory concentration: 11800 nM
Compound 4: middle estimate off by 1.3-fold (0.12 log units), on the low side; low and high end bracket the measured number.
By their numbers in this assay, from the lowest: compound 2; then compounds 1, 4 and 3 (each within the scatter of the next).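

Placing dimethylamino on this aromatic carbon, with 0 hydrogen-bond donors against 2 for (2-hydroxyethyl)amino, brings no separation in this assay (a 1.3-fold lower number from compound 3 to compound 4 (0.11 log units; within the scatter)). The same holds against 3-oxopiperazin-1-yl (a 1.2-fold higher number from compound 1 to compound 4 (0.09 log units; within the scatter)), while (2-aminoethyl)amino alone stands apart (a 3.7-fold higher number from compound 2 to compound 4 (0.57 log units; beyond the scatter)), so among these four compounds only that group gives a step beyond the scatter. No evidence on the cause is available. Still open, on these data alone, is whether the terminal amino group needs its chain: a longer chain such as (3-aminopropyl)amino might match compound 2 or fall back to the other three.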